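This account rests on a few compounds, and the source may have more. Where it says the series, first, only, none or still open, it means among the compounds named here.

For the measured compounds named here, compound 1 (`COc1cc(C)c(-c2cccc(COc3ccc(S(=O)(=O)CC(=O)O)cc3)c2)c(C)c1`) is the only compound in this small set with a number in a physicochemical assay for lipophilicity, using the shake flask method, in phosphate buffer, measured as octanol-water partition, with a stated time of 24 h, at pH 7.4, tested at 100 uM (a higher number here means a more lipophilic compound, a lower number a more polar compound), where compound 1 gives 2.45 as its reading. Two relatives offer no comparison in this assay because compound 2 (`COc1cc(C)c(-c2cccc(COc3ccc4c(c3)SCC4CC(=O)O)c2)c(C)c1`) stands at "not determined" (no result reported) and compound 3 (`COc1cc(C)c(-c2cccc(COc3ccc4c(c3)C(=O)CC4CC(=O)O)c2)c(C)c1`) stands at "not determined" (no result reported) in the record. Compound 1 therefore has no measured neighbour to be ranked against.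

Compound 4 (`Cc1cc(OCC2CC2)cc(C)c1-c1cccc(COc2ccc(S(=O)(=O)CC(=O)O)cc2)c1`) keeps the core of compound 1 and differs in one place, on a saturated chain carbon bound to an oxygen on an aromatic ring. The change reads cyclopropyl in place of hydrogen on a saturated chain carbon bound to an oxygen on an aromatic ring and turns methoxy into cyclopropylmethoxy.

Going by the values given here, no measured pair shows what such a change does, so the expectation rests on the structure alone. Starting from compound 1 at 2.45 and adding a ring of carbon only, with no hydrogen-bond donors or acceptors, an upward move beyond the usual scatter is expected. The expected size is a number 0.75 log units higher from compound 1 to compound 4 (beyond the scatter) on this estimate. For compound 4 the estimated value is 3.2 within an expected range of 2.8 to 3.7 in this assay as it stands.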

Compound 4, distribution coefficient: 3.46
The estimate for compound 4 lay 0.26 log units below the measured number, and the stated range covers the measured number.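

Compound 1 had no measured neighbour, but the place on a saturated chain carbon bound to an oxygen on an aromatic ring can now be seen to matter in this assay: turning methoxy into cyclopropylmethoxy gives a number 1.01 log units higher from compound 1 to compound 4 (beyond the scatter), a large step. This single pair shows that a change of only 3 carbon heavy atoms, with no hydrogen-bond donors or acceptors and no net charge, is enough to move the reading clearly. Nothing measured here accounts for the size of this step.

As far as these compounds go, with one pair, it remains open whether the step follows the three-membered ring itself or simply the added carbon, which a straight propyl chain at the same place could help to separate. From the compounds shown here alone, how an amine or a hydroxyl group at this place would shift the reading in this assay also remains open.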